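This account rests on a few compounds, and the source may have more. Where it says the series, first, only, none or still open, it means among the compounds named here.

Compound 2 `O=C(CN1CCN(c2ccccn2)CC1)Nc1cccnc1` gives the highest of the two numbers recorded in a functional assay on cells for antagonist activity at D(4) dopamine receptor (Homo sapiens), read by TR-FRET and cAMP accumulation, with a stated time of 30 min (a higher number here means a weaker inhibitor, a lower number a stronger inhibitor), where compound 2 gives 86500 nM. Its nearest neighbour is compound 1 `CCc1cccc(NC(=O)CN2CCN(c3ccccn3)CC2)c1`, which in this assay gives 1310 nM; the two differ only in the group on the amide-type nitrogen, and the step of a 66-fold higher number from compound 1 to compound 2 (1.82 log units; beyond the scatter) lies well beyond the scatter. Compound 3 `O=C(CN1CCN(c2ccccn2)CC1)Nc1cncnc1` carries the change (pyrimidin-5-yl in place of pyridin-3-yl on an amide-type nitrogen). Among the measured compounds shown here, the only measured step that bears on this change is the one from compound 1 to compound 2, in which a ring nitrogen entered the same position and the number rose sharply. A second ring nitrogen is therefore expected to move the number further in the same direction, though by a smaller margin, so the step of a 2.3-fold higher number from compound 2 to compound 3 (0.36 log units; beyond the scatter) is estimated as a moderate rise. Compound 3 is thus expected to give 200000 nM in this assay, within a range of 60000 nM to 700000 nM.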

Compound 3, half-maximal inhibitory concentration: > 100000 nM
Compound 3: no number, only a limit (the forecaster's own chance of this, stated with the estimate: 40%); the middle value does not contradict the limit.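

In this assay compound 3 gives only a limit, > 100000 nM, and not a number: the limit of > 100000 nM in this assay, at which 1 of the 3 values shown sits. At this position the pyrimidin-5-yl group therefore adds less information than the earlier pair did, and the step of an at least 1.1-fold higher number from compound 2 to compound 3 (0.06 log units; that floor lies within the scatter) has a floor that does not separate it from pyridin-3-yl. What is new is that a second heteroaromatic ring on the amide-type nitrogen also stays far from 3-ethylphenyl, as the step of an at least 76-fold higher number from compound 1 to compound 3 (1.88 log units; beyond the scatter) shows.

Going by these compounds, how far the true value of compound 3 lies past its limit stays open, so the effect of the added ring nitrogen cannot be sized. On these data alone, it is also open whether the gap to compound 1 follows the ring nitrogen or the ethyl group, a question that an unsubstituted phenyl group on the same nitrogen would address.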